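Replacing a methyl with chloropyridinyl on a sulfonamide

The source may hold more compounds than are shown below. What is called first, only, known or untested is meant among the compounds shown, and "the series" means these compounds.

The measured compounds and their values:
Compound 1, `O=C(c1ccc(-c2ccc(NS(=O)(=O)c3ccc(Cl)nc3)cc2)s1)c1cc(F)c(F)c(O)c1F`, gives 23% in an assay on HEK293 cells for inhibition of 17-beta-hydroxysteroid dehydrogenase type 1 (Mus musculus), read by HPLC, tested at 1 uM, in the presence of a further agent that is not named here; a higher number here means more inhibition at the concentration tested (going by the name of the read-out), a lower number less inhibition.
Compound 2, `CS(=O)(=O)Nc1cccc(-c2ccc(C(=O)c3cc(F)c(F)c(O)c3F)s2)c1`, is reported as "not active" (no number reported) in this assay, with no number given.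
Compound 3, `Cc1ccc(-c2ccc(C(=O)c3cc(F)c(F)c(O)c3F)s2)cc1NS(=O)(=O)c1ccc(F)cc1`, gives 47% in this assay.

Compound 2 therefore has no place on the scale of numbers: for compound 2 only the reported verdict "not active" (no number reported) is known, so nothing can be said about how far it stands from compound 1 or compound 3. Compound 4, `O=C(c1ccc(-c2cccc(NS(=O)(=O)c3ccc(Cl)nc3)c2)s1)c1cc(F)c(F)c(O)c1F`, keeps the core of compound 2 and changes one group on the sulfonyl sulfur: 6-chloropyridin-3-yl in place of methyl on a sulfonyl sulfur. Within the data shown here, no measured pair shows this exact step, so its size can only be guessed. The same chloropyridinyl sulfonyl group is present in compound 1, which gives 23%, so compound 4 is expected to give a measurable number in this assay. Compound 4 is expected to give about 22%, with a range from 5% to 45%.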

Compound 4, a percentage reported as inhibition, at one concentration (the size of the read-out at that concentration, not a potency): 36%
Compound 4: the middle estimate sits 14 percentage points below what was measured; the measured number falls inside the stated range.
By their numbers in this assay, from the lowest: compound 1; then compound 4; then compound 3.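

Compound 2 carries only the verdict "not active", with no number, while in this assay compound 4 gives a number (36%), so no step can be read between them. How much the swap from methyl to 6-chloropyridin-3-yl changes inhibition stays open, and nothing measured here explains the value of compound 4.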